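Aryl variation on the saturated ring carbon of the series

The compounds below may be only part of what the source reports. "The series", "measured", "known", "first", "only" and "open" are said of these compounds alone.

Measured compounds:
compound 1 `CC(=O)N1N=C(c2ccc3ccccc3c2)OC1c1cccc(Br)c1` — 2.36 ug/mL
compound 2 `CC(=O)N1N=C(c2ccc3ccccc3c2)OC1c1ccccc1Cl` — 4.93 ug/mL
compound 3 `CC(=O)N1N=C(c2ccc3ccccc3c2)OC1c1ccccn1` — 7.18 ug/mL

All three share one core and differ only in the aryl group on the saturated ring carbon. In a functional assay on B16-F10 cells (Mus musculus) for antiproliferative activity, read by MTT assay, with a stated time of 48 h (on this read-out lower numbers stand for stronger inhibition and higher numbers for weaker inhibition), compound 2 gives 4.93 ug/mL, the second highest of the three numbers: its nearest neighbour is compound 3, with a 1.5-fold higher number from compound 2 to compound 3 (0.16 log units; within the scatter), and its furthest is compound 1, with a 2.1-fold higher number from compound 1 to compound 2 (0.32 log units; beyond the scatter) separating them.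

The next compound, compound 4 `CC(=O)N1N=C(c2ccc3ccccc3c2)OC1c1ccsc1`, carries thiophen-3-yl in place of 2-chlorophenyl on a saturated ring carbon.

Going by the values given here, two measured steps bear on this: the change of aryl group from compound 1 gave a 2.1-fold higher number from compound 1 to compound 2 (0.32 log units; beyond the scatter), and the change from compound 2 gave a 1.5-fold higher number from compound 2 to compound 3 (0.16 log units; within the scatter). Swapping one aryl group for another on this carbon has so far moved the number by modest amounts at most, with no direction that the thiophen-3-yl group can be tied to. A step within the scatter of compound 2, or a small rise, is therefore expected.

Compound 4 is estimated at 5.5 ug/mL in this assay, with a range of 2.5 ug/mL to 12 ug/mL, which means an expected step of a 1.1-fold higher number from compound 2 to compound 4 (0.05 log units; within the scatter).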

Compound 4, half-maximal inhibitory concentration: 8.56 ug/mL
Compound 4: the middle estimate sits 1.6-fold (0.19 log units) below what was measured; low and high end bracket the measured number.
By their numbers in this assay, from the lowest: compound 1; then compounds 2, 3 and 4 (each within the scatter of the next).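

On the saturated ring carbon, a five-membered aromatic ring with one sulfur atom gives no clear separation from the two groups closest to it in this assay: a 1.7-fold higher number from compound 2 to compound 4 (0.24 log units; within the scatter), and a 1.2-fold higher number from compound 3 to compound 4 (0.08 log units; within the scatter). Thiophen-3-yl, 2-chlorophenyl and pyridin-2-yl therefore cannot be ordered, whereas compound 1 stands apart from all three others as the strongest of the set, now also with a 3.6-fold higher number from compound 1 to compound 4 (0.56 log units; beyond the scatter). No measurement shown here accounts for the separate standing of the 3-bromophenyl group.

From the compounds shown here alone, it remains open whether that standing follows the bromine itself or its place on the phenyl ring, a question that 3-chlorophenyl and 2-bromophenyl groups would address. Going by these compounds, how an aminophenyl or carboxyphenyl group would read on this carbon also remains open.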